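Aryl replacement in compound 1: expectation for compound 4

The source may report more compounds than this note shows. Statements on the series, on what has been measured and on what is new or still open speak of the compounds shown alone.

Measured in a functional assay on SW 1116 cells (Homo sapiens) for cytotoxicity, read by MTT assay, with a stated time of 48 h (on this read-out higher numbers stand for weaker inhibition and lower numbers for stronger inhibition), so far:
compound 1 `O=C(CSc1nnc(-c2ccncc2)o1)N/N=C/c1ccc(Br)cc1` gives 21300 nM
compound 2 `O=C(CSc1nnc(-c2ccncc2)o1)N/N=C/c1ccccc1F` gives 21500 nM
compound 3 `O=C(CSc1nnc(-c2ccncc2)o1)N/N=C/c1ccccc1O` gives 7380 nM

Compound 1 stands second highest of the three numbers: compound 2 sits within the scatter of it, a 1.0-fold higher number from compound 1 to compound 2 (0.00 log units; within the scatter), while compound 3 lies furthest from it, a 2.9-fold lower number from compound 1 to compound 3 (0.46 log units; beyond the scatter), a modest step beyond the scatter.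

Compound 4 `COc1cc(/C=N/NC(=O)CSc2nnc(-c3ccncc3)o2)ccc1O` differs from compound 1 in one place: 4-hydroxy-3-methoxyphenyl in place of 4-bromophenyl on a carbon with a double bond to nitrogen. For the measured compounds named here, two measured steps bear on this. Exchanging 4-bromophenyl for 2-fluorophenyl left the number unchanged, a 1.0-fold higher number from compound 1 to compound 2 (0.00 log units; within the scatter), whereas placing a hydroxy group on the ring gave a modest lowering, a 2.9-fold lower number from compound 1 to compound 3 (0.46 log units; beyond the scatter) and a 2.9-fold lower number from compound 2 to compound 3 (0.46 log units; beyond the scatter). Going by the values given here, compound 4 also carries a hydroxy group, alongside a methoxy group, so a modest step toward a lower number in this assay is expected, though no measured compound carries this exact arrangement.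

Compound 4 is therefore estimated at 10000 nM in this assay, with a range of 4000 nM to 25000 nM, corresponding to an expected step of a 2.1-fold lower number from compound 1 to compound 4 (0.33 log units; beyond the scatter).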

Compound 4, half-maximal inhibitory concentration: 3590 nM
Beside the measured number, compound 4's estimate is 2.8-fold (0.44 log units) above it; the whole stated range lies above it.
By their numbers in this assay, from the lowest: compound 4; then compound 3; then compounds 1 and 2 (each within the scatter of the next).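

In this assay, for the compounds shown here, this position allows a wider span than the earlier compounds showed: 4-hydroxy-3-methoxyphenyl gives a 5.9-fold lower number from compound 1 to compound 4 (0.77 log units; beyond the scatter) and a 6.0-fold lower number from compound 2 to compound 4 (0.78 log units; beyond the scatter), each step larger than any among the first three compounds. A hydroxy group on the ring does not by itself set the number, as the step from the 2-hydroxyphenyl group, a 2.1-fold lower number from compound 3 to compound 4 (0.31 log units; beyond the scatter), separates two hydroxy-bearing aryl groups and leaves compound 4 lowest of the series, with its steps to all others beyond the scatter. No information is available to explain these differences.

The compounds shown do not separate the contribution of the hydroxy group from that of the methoxy group, since the two enter together in compound 4. Also open, from the compounds shown here alone, is how an aryl ring carrying an amine or a carboxylic acid would read at this place.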